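From nitro to fluoro at one position

This account rests on a few compounds, and the source may have more. Where it says the series, first, only, none or still open, it means among the compounds named here.

Compound 1 (`O=[N+]([O-])c1ccccc1Nc1nnc(-c2c[nH]c3ccccc23)o1`), compound 2 (`O=[N+]([O-])c1cccc(Nc2nnc(-c3c[nH]c4ccccc34)o2)c1`) and compound 3 (`O=[N+]([O-])c1ccc(Nc2nnc(-c3c[nH]c4ccccc34)o2)cc1`) share one core and differ only in where the nitro group sits. In a functional assay on MDA-MB-231 cells (Homo sapiens) for inhibition, read by MTT assay, with a stated time of 72 h (on this read-out lower numbers stand for stronger inhibition and higher numbers for weaker inhibition), compound 1 gives 900 nM as its value, compound 2 gives 34600 nM and compound 3 gives 3540 nM in the same test. Compound 3 therefore stands in the middle of the three, weaker than compound 1 and stronger than compound 2, with both gaps beyond the usual scatter.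

Compound 4 (`Fc1ccc(Nc2nnc(-c3c[nH]c4ccccc34)o2)cc1`) keeps the core of compound 3 but has fluoro in place of nitro on an aromatic carbon, para to a large group (fluoro in place of nitro on an aromatic carbon). Among the compounds with values here, no measured pair yet shows what this swap does. In this assay the expectation is no change beyond the scatter and no firm direction, with a 1.2-fold lower number from compound 3 to compound 4 (0.07 log units; within the scatter) as the estimated step. The gap between compound 1 at 900 nM and compound 2 at 34600 nM shows how far values spread in this small set, so the range stays wide. Compound 4 is estimated at 3000 nM with a range from 700 nM to 13000 nM as the expected span.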

Compound 4, half-maximal inhibitory concentration: > 100000 nM
Compound 4 ended at the assay's limit; the forecaster's own chance of this, stated with the estimate: 5%; middle value at least 33-fold (1.52 log units) from the limit.
By their numbers in this assay, from the lowest: compound 1; then compound 3; then compound 2. At a limit, above all of these: compound 4.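

In this assay, within the data shown here, the earlier compounds showed only that moving the nitro group changes the result, whereas changing the group itself at this place, para to a large group, gives an at least 28-fold higher number from compound 3 to compound 4 (1.45 log units; beyond the scatter). Compound 4 sits at a limit, so its result is not an exact number: the limit of > 100000 nM in this assay, at which 1 of the 4 values shown sits. In this one pair, then, nitro cannot be exchanged for fluoro at this place without losing inhibition that can be measured in this test, even though fluoro is the smaller group by count of heavy atoms.

From the compounds shown here alone, whether an amine or a carboxylic acid at the same place would keep the inhibition of compound 3 remains open. Also open, going by these compounds, is what fluoro would do at the places the nitro group occupies in compound 1 and compound 2.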